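Extending an aryl amine by one carbon in a chromene series

The compounds below may be only part of what the source reports. "The series", "measured", "known", "first", "only" and "open" are said of these compounds alone.

Compound 1 `COC(=O)CC1C(C(=O)OC)=C(N)Oc2ccc(-c3cc(OC)cc(OC)c3)cc21` gives 2420 nM in a functional assay on HL-60 cells (Homo sapiens) for cytotoxicity, read by CellTiter-Blue, with a stated time of 48 h; on this read-out higher numbers stand for weaker inhibition and lower numbers for stronger inhibition. Compound 2 `CCOC(=O)CC1C(C(=O)OC)=C(N)Oc2ccc(-c3cc(OC)cc(OC)c3)cc21` gives 10800 nM in this assay. The change between them, (methyl in place of hydrogen on a saturated chain carbon bound to an oxygen next to a carbonyl group), produced a 4.5-fold higher number from compound 1 to compound 2 (0.65 log units; beyond the scatter). Compound 3 `C#CCOC(=O)CC1C(C(=O)OCC)=C(N)Oc2ccc(-c3cccc(NC)c3)cc21` gives 7130 nM; how its core differs from the core of compound 1 is not broken down here. Compound 4 `C#CCOC(=O)CC1C(C(=O)OCC)=C(N)Oc2ccc(-c3cccc(NCC)c3)cc21` carries the change (methyl in place of hydrogen on a saturated chain carbon bound to a nitrogen on an aromatic ring). This is the same kind of change as the earlier one, but not the same: here the carbon is bound to a nitrogen on an aromatic ring rather than to an oxygen next to a carbonyl group. Within the data shown here, only a modest step is expected, a 1.3-fold higher number from compound 3 to compound 4 (0.10 log units; within the scatter), because a 4.5-fold higher number from compound 1 to compound 2 (0.65 log units; beyond the scatter) occurred at a different place and is the sole precedent. Compound 4 is estimated at 9000 nM, likely between 3500 nM and 24000 nM.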

Compound 4, half-maximal inhibitory concentration: 17200 nM
Compound 4: middle estimate off by 1.9-fold (0.28 log units), on the low side; low and high end bracket the measured number.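

Adding the methyl turns methylamino into ethylamino and gives a 2.4-fold higher number from compound 3 to compound 4 (0.38 log units; beyond the scatter) in this assay. Set beside the earlier change at the ester, the same addition gives a higher number on both cores, and the two steps do not differ by more than the scatter allows: the same change on two cores in this assay, a 4.5-fold higher number (0.65 log units; beyond the scatter) from compound 1 to compound 2 and a 2.4-fold higher number (0.38 log units; beyond the scatter) from compound 3 to compound 4, 1.8-fold (0.27 log units) apart, within the scatter of two such steps. Among these compounds, with only two pairs, at different places on different cores, this shows agreement in these two cases, but it does not show that the change would carry over to any other core or place.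

Still open, on these data alone, is whether a longer chain such as propyl on that nitrogen would raise the number further. A plain amine in place of methylamino is also not covered by the compounds shown, so its effect on the number remains unknown.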